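This account rests on a few compounds, and the source may have more. Where it says the series, first, only, none or still open, it means among the compounds named here.

Measured in an assay on CHO cells for displacement of a labelled ligand from adenosine receptor A1 (Homo sapiens); on this read-out higher numbers stand for weaker inhibition and lower numbers for stronger inhibition:
Compound 1 `CCCn1c(=O)c2nc(-c3cnn(Cc4cc(Cl)ccc4Cl)c3)[nH]c2n(CCC)c1=O` gives 190 nM.
Compound 2 `Cn1c(=O)c2[nH]c(-c3cnn(Cc4cccc(F)c4)c3)nc2n(C)c1=O` gives 460 nM.
Compound 3 `CCCn1c(=O)c2nc(-c3cnn(Cc4cccc(Cl)c4)c3)[nH]c2n(CCC)c1=O` gives 31 nM.

Compound 1 sits second highest of the three numbers in this assay. Among the compounds with values here, its nearest neighbour is compound 2, whose number is higher; no single-point step connects the two, so only the two values themselves can be compared. Within the data shown here, the one step that connects compound 1 to another measured compound is a 6.1-fold lower number from compound 1 to compound 3 (0.79 log units; beyond the scatter), a modest but clear move to a lower number when one chloro is taken off the benzyl group.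

Compound 4 `CCCn1c(=O)c2nc(-c3cnn(Cc4ccccc4OC)c3)[nH]c2n(CCC)c1=O` is not yet measured. It differs from compound 1 as follows: 2-methoxyphenyl in place of 2,5-dichlorophenyl on a saturated chain carbon bound to an aromatic nitrogen. Among the measured compounds shown here, both chlorines of compound 1 leave and a methoxy group enters, so the change is not the same as the one between compound 1 and compound 3, and no measured step covers a methoxy group on this benzyl. The step from compound 1 to compound 3 suggests that losing chloro from this ring is tolerated or helpful, so a number at or somewhat below that of compound 1 is expected for compound 4, though with wide uncertainty. Estimated value for compound 4 in this assay: 110 nM, range 30 nM to 400 nM, which would correspond to an expected step of a 1.7-fold lower number from compound 1 to compound 4 (0.24 log units; within the scatter).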

Compound 4, inhibition constant: 59 nM
Compound 4: middle estimate off by 1.9-fold (0.27 log units), on the high side; low and high end bracket the measured number.
By their numbers in this assay, from the lowest: compounds 3 and 4 (each within the scatter of the next); then compound 1; then compound 2.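

In this assay, the step from 2,5-dichlorobenzyl to 2-methoxybenzyl gives a 3.2-fold lower number from compound 1 to compound 4 (0.51 log units; beyond the scatter) and shows that this place on the saturated chain carbon bound to an aromatic nitrogen accepts a benzyl group carrying methoxy and no chloro, with one hydrogen-bond acceptor entering where none left. The change from 3-chlorophenyl to 2-methoxyphenyl gives a 1.9-fold higher number from compound 3 to compound 4 (0.28 log units; within the scatter) and so does not separate these two groups, which means that a chloro on the benzyl ring is not required for a number in this range. The data at hand offer no measured reason for either step.

The compounds shown leave open whether the lower number of compound 4 relative to compound 1 comes from the loss of both chlorines or from the entry of methoxy, a question that a plain unsubstituted benzyl group would help to settle. Also open, going by these compounds, is how far this place accepts other kinds of group, such as ethoxy, a dimethylamino group or a carboxylic acid on the benzyl ring.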